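The source may hold more compounds than are shown below. What is called first, only, known or untested is meant among the compounds shown, and "the series" means these compounds.

Working notes on the series. Compound 3 `COc1ccc(-c2cc(/C=C/C(=O)c3ccccc3)nc3cc(-c4ccccc4)nn23)cc1` gives 9900 nM in a functional assay on MDA-MB-231 cells (Homo sapiens) for antiproliferative activity, read by MTT assay, with a stated time of 24 h (a lower number here means a stronger inhibitor, a higher number a weaker inhibitor), the lowest number of the three shown, although compound 2 `COc1ccc(-c2cc(/C=C/C(=O)c3ccc(C)c(C)c3)nc3cc(-c4ccccc4)nn23)cc1OC` lies within the scatter of it at 11500 nM; compound 1 `COc1ccc(-c2cc(C(=O)/C=C/c3ccccc3)nc3cc(-c4ccccc4)nn23)cc1OC` gives 23300 nM, beyond the scatter. Among the compounds with values here, the one step that can be computed, a 2.0-fold lower number from compound 1 to compound 2 (0.31 log units; beyond the scatter), is modest and concerns the other arm of the core, not the aryl ring that carries the methoxy group.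

Compound 4 `COc1ccc(-c2cc(/C=C/C(=O)c3ccccc3)nc3cc(-c4ccccc4)nn23)cc1OC` differs from compound 3 by methoxy in place of hydrogen on an aromatic carbon; cut one bond further out, the change reads 4-methoxyphenyl to 3,4-dimethoxyphenyl. Within the data shown here, no measured step isolates this change. What the numbers do show is that compound 1 and compound 2, both carrying the 3,4-dimethoxyphenyl group, fall in the same region of this assay as compound 3, one within the scatter of it and one somewhat beyond. The step of a 1.2-fold higher number from compound 3 to compound 4 (0.08 log units; within the scatter) is therefore expected to be no larger than the usual scatter, in no firm direction. For compound 4 in this assay the estimate is 12000 nM, with a range from 5000 nM to 28000 nM.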

Compound 4, half-maximal inhibitory concentration: 11800 nM
Compound 4: the middle estimate sits 1.0-fold (0.01 log units) above what was measured; low and high end bracket the measured number.
By their numbers in this assay, from the lowest: compounds 3, 2, 4 and 1 (each within the scatter of the next, the first and the last beyond it).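

In this assay, the change from 4-methoxyphenyl to 3,4-dimethoxyphenyl is now isolated as a single step, and a 1.2-fold higher number from compound 3 to compound 4 (0.08 log units; within the scatter) shows that the added methoxy does not separate the two compounds at this position. On the other arm, the change from 3,4-dimethylphenyl to phenyl on the carbonyl carbon gives a 1.0-fold higher number from compound 2 to compound 4 (0.01 log units; within the scatter) and likewise does not separate the pair, so neither the methyl groups nor the added methoxy can be read as changing the number here. Replacing (2-phenylethenyl)carbonyl with 2-benzoylethenyl gives a 2.0-fold lower number from compound 1 to compound 4 (0.30 log units; within the scatter) and also stays within the scatter, so this pair does not establish a preference between the two linkers. No independent evidence bears on these results.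

On these data alone, whether the ring carrying the methoxy groups would give a different number with a hydroxy group, an amine or a longer ethoxy chain remains open. Also open, as far as these compounds go, is whether the closeness of compounds 2, 3 and 4 would hold outside this assay.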